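The source may hold more compounds than are shown below. What is called first, only, known or untested is meant among the compounds shown, and "the series" means these compounds.

Working notes on the series. In a functional assay on OVCAR-5 cells (Homo sapiens) for inhibition, read by CCK-8 assay, with a stated time of 72 h, tested at 1 uM (a higher number here means more inhibition of growth at the concentration tested, a lower number less inhibition of growth), compound 1 (`CN(C)C(=O)c1cc2cnc(Nc3ccc(NC(=O)C4(C(=O)Nc5ccc(Cl)cc5)CC4)cc3)nc2n1C1CCCC1`) gives 8.1%. Compound 3 (`CN(C)C(=O)c1cc2cnc(Nc3ccc(NC(=O)C4(C(=O)Nc5cccc(Cl)c5)CC4)cc3)nc2n1C1CCCC1`) gives 15.5%, which is a number 7.4 percentage points higher from compound 1 to compound 3 (within the scatter), so the two stand level. Compound 2 (`CN(C)C(=O)c1cc2cnc(Nc3ccc(NC(=O)C4(C(=O)Nc5ccccc5F)CC4)cc3)nc2n1C1CCCC1`) gives 58%, which is a number 49.9 percentage points higher from compound 1 to compound 2 (beyond the scatter). Going on to the 3-chlorophenyl amide gives a number 42.5 percentage points lower from compound 2 to compound 3 (beyond the scatter), so compound 2 stands clear of the other two.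

The next compound is compound 4 (`CN(C)C(=O)c1cc2cnc(Nc3ccc(NC(=O)C4(C(=O)Nc5cccc(Br)c5)CC4)cc3)nc2n1C1CCCC1`), with 3-bromophenyl in place of 4-chlorophenyl on an amide-type nitrogen. The measured step that bears most directly on this change is the one to the 3-chlorophenyl amide, a number 7.4 percentage points higher from compound 1 to compound 3 (within the scatter). Going by the values given here, the large step to the 2-fluorophenyl amide, a number 49.9 percentage points higher from compound 1 to compound 2 (beyond the scatter), gives a warning that this amide substituent can matter, but no bromine compound has been measured yet.

The step expected is a number 7.9 percentage points higher from compound 1 to compound 4 (within the scatter), so no change beyond the scatter is anticipated. For compound 4 the estimated value is 16%, with an expected range of 4% to 35%.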

Compound 4, percent growth inhibition at one concentration: 0.04%
The estimate for compound 4 lay 16 percentage points above the measured number, and the stated range ends above it.
By their numbers in this assay, from the lowest: compounds 4, 1 and 3 (each within the scatter of the next, the first and the last beyond it); then compound 2.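

In this assay, the 3-bromophenyl amide sits level with the 4-chlorophenyl amide, with a number 8.1 percentage points lower from compound 1 to compound 4 (within the scatter), but bromo in place of chloro on the same aromatic carbon gives a number 15.5 percentage points lower from compound 3 to compound 4 (beyond the scatter), the first sign that the identity of the halogen alone can move this number, though only modestly. The 2-fluorophenyl amide remains apart, with a number 58 percentage points lower from compound 2 to compound 4 (beyond the scatter), so compound 2 now stands clear of three other halophenyl amides. Nothing measured here accounts for either step.

The compounds shown cannot separate the contribution of fluoro from that of its place on the ring in compound 2. Also open, going by these compounds, is how this amide behaves with plain phenyl, or with a methoxy group or an amine in place of the halogen.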